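Vinyl for prop-1-en-1-yl at the amide carbonyl

The source may hold more compounds than are shown below. What is called first, only, known or untested is meant among the compounds shown, and "the series" means these compounds.

Two compounds on the shared core have numbers. In a functional assay on Z-138 cells (Homo sapiens) for inhibition, read by luminescence and CellTiter-Glo, with a stated time of 72 h (on this read-out lower numbers stand for stronger inhibition and higher numbers for weaker inhibition), compound 1 `C=CC(=O)Nc1ccc(Cn2nc(-c3ccc(Oc4ccccc4)cc3)cc2C(=O)OCC)cc1` gives 12500 nM. Compound 2 `C/C=C/C(=O)Nc1ccc(Cn2nc(-c3ccc(Oc4ccccc4)cc3)cc2CO)cc1` gives 54500 nM in this assay, the highest of the two numbers, with a gap to compound 1 that lies beyond the scatter. Compound 3 `C=CC(=O)Nc1ccc(Cn2nc(-c3ccc(Oc4ccccc4)cc3)cc2CO)cc1` differs from compound 2 by vinyl in place of prop-1-en-1-yl on a carbonyl carbon. Going by the values given here, no measured pair shows this change, so its size is not known. A move to a lower number, beyond the scatter, is expected for the step of a 3.0-fold lower number from compound 2 to compound 3 (0.48 log units; beyond the scatter). Compound 3 is accordingly estimated at 18000 nM, with a range from 6000 nM to 50000 nM.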

Compound 3, half-maximal inhibitory concentration: 6800 nM
Estimate against measurement, compound 3: 2.6-fold (0.42 log units) above; low and high end bracket the measured number.
By their numbers in this assay, from the lowest: compounds 3 and 1 (each within the scatter of the next); then compound 2.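

At the carbonyl carbon, the change from prop-1-en-1-yl to vinyl now has a measured size in this assay: an 8.0-fold lower number from compound 2 to compound 3 (0.90 log units; beyond the scatter), so this position responds to a change of this small group. With vinyl on both compounds, hydroxymethyl in place of ethoxycarbonyl on an aromatic carbon gives a 1.8-fold lower number from compound 1 to compound 3 (0.26 log units; within the scatter), so this pair shows no readable difference. Nothing at hand explains either step.

Still open, going by these compounds, is how an ethyl group on the carbonyl carbon would compare with vinyl. Also open, on these data alone, is how a carboxylic acid on the aromatic carbon would compare with hydroxymethyl.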